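A few compounds are considered here, and "the series" means these few. Any claim that something is new, unique, unknown or untested is made for them only; others in the source may bear on it.

Measured in a functional assay on HCT-15 cells (Homo sapiens) for antiproliferative activity; on this read-out lower numbers stand for stronger inhibition and higher numbers for weaker inhibition:
- compound 1 `COc1ccc(S(=O)(=O)Oc2ccccc2NC(=O)c2ccccn2)cc1`: 110 nM
- compound 2 `COc1ccc(S(=O)(=O)Oc2ccccc2NC(=O)Oc2ccccc2)cc1`: > 10000 nM (a limit, not a number)

Compound 2 gives only a limit: the limit of > 10000 nM in this assay, at which 1 of the 2 values shown sits. Compound 3 `COc1ccc(S(=O)(=O)Oc2ccccc2NC(=O)c2ccccc2)cc1` changes one group, with phenyl in place of phenoxy on a carbonyl carbon. Among the compounds with values here, one measured step bears on this: an at least 90-fold higher number from compound 1 to compound 2 (1.95 log units; beyond the scatter), a large loss on introducing phenoxy at that same carbonyl carbon. With phenoxy gone, a large move towards lower numbers in this assay is expected, in the direction of compound 1 at 110 nM. The expected change is an at least 20-fold lower number from compound 2 to compound 3 (1.30 log units; beyond the scatter). Compound 3 is estimated at 500 nM, within a range of 80 nM to 5000 nM.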

Compound 3, half-maximal inhibitory concentration: 310 nM
Estimate against measurement, compound 3: 1.6-fold (0.21 log units) above; the range from low to high includes it.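

In this assay, the two groups that differ by a single oxygen behave very differently on this carbonyl carbon, with phenyl restoring activity: an at least 32-fold lower number from compound 2 to compound 3 (1.50 log units; beyond the scatter). Phenyl does not fully match pyridin-2-yl, as the smaller step shows: a 2.8-fold higher number from compound 1 to compound 3 (0.45 log units; beyond the scatter). The first step gives only a minimum size, because compound 2 sits at a limit: the limit of > 10000 nM in this assay, at which 1 of the 3 values shown sits.

From the compounds shown here alone, it remains open how a benzyl group, a cyclohexyl ring or a dimethylamino group would behave on this carbonyl carbon. Going by these compounds, whether the same order of groups holds in other cell lines also remains open.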